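Chlorophenyl placement and growth inhibition in the series

The source may hold more compounds than are shown below. What is called first, only, known or untested is meant among the compounds shown, and "the series" means these compounds.

Measured so far in a functional assay on 786-0 cells (Homo sapiens) for inhibition, read by sulforhodamine B assay, with a stated time of 48 h; on this read-out higher numbers stand for weaker inhibition of growth and lower numbers for stronger inhibition of growth:
compound 1 `CC1=CC[C@H](C(C)(C)NC(=S)N/N=C/c2ccc(F)cc2)CC1` gives > 100000 nM, a limit of the assay
compound 2 `CC1=CC[C@H](C(C)(C)NC(=S)N/N=C/c2ccccc2Cl)CC1` gives 85500 nM
compound 3 `CC1=CC[C@H](C(C)(C)NC(=S)N/N=C/c2cccc(Cl)c2)CC1` gives 9200 nM

Compound 3 holds the lowest of the two numbers in this assay; compound 2 is its nearest neighbour, and the step of a 9.3-fold lower number from compound 2 to compound 3 (0.97 log units; beyond the scatter) lies beyond the scatter. Compound 1 contributes only a limit, (the limit of > 100000 nM in this assay, at which 1 of the 3 values shown sits).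

Compound 4 `CC1=CC[C@H](C(C)(C)NC(=S)N/N=C/c2ccc(Cl)cc2)CC1` differs from compound 3 in one place: 4-chlorophenyl in place of 3-chlorophenyl on a carbon with a double bond to nitrogen. Among the compounds with values here, no measured step moves a chlorine from the 3-chlorophenyl to the 4-chlorophenyl position. The steps that come closest are an at least 10-fold lower number from compound 1 to compound 3 (1.03 log units; beyond the scatter) and a 9.3-fold lower number from compound 2 to compound 3 (0.97 log units; beyond the scatter), both pointing to the 3-chlorophenyl as the arrangement with the lowest number. As far as these compounds go, the 4-fluorophenyl of compound 1 sits at a limit, and a chlorine in the same position is untested. On that basis the expected step of a 4.3-fold higher number from compound 3 to compound 4 (0.64 log units; beyond the scatter) is upward in this assay, with a real chance that only a limit is reported. Compound 4 is therefore estimated at 40000 nM, within 8000 nM to 150000 nM.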

Compound 4, concentration for 50% growth inhibition: 74900 nM
The estimate for compound 4 lay 1.9-fold (0.27 log units) below the measured number, within the range that was stated.
By their numbers in this assay, from the lowest: compound 3; then compounds 4 and 2 (each within the scatter of the next). At a limit, above all of these: compound 1.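

In this assay the chlorine has now been placed in all three ring positions, and an 8.1-fold higher number from compound 3 to compound 4 (0.91 log units; beyond the scatter) shows that the lower number belongs to the 3-chlorophenyl and is not shared by the 4-chlorophenyl. The other two chlorophenyl compounds cannot be told apart: the step between them is a 1.1-fold lower number from compound 2 to compound 4 (0.06 log units; within the scatter). Among these three the result is therefore a single low compound and not a graded trend in chlorine position. The step of chloro in place of fluoro, an at least 1.3-fold lower number from compound 1 to compound 4 (0.12 log units; that floor lies within the scatter), cannot be read, since compound 1 stands at a limit: the limit of > 100000 nM in this assay, at which 1 of the 4 values shown sits.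

Still open, as far as these compounds go, is whether the lower number depends on chlorine itself, which a 3-bromophenyl, 3-methoxyphenyl or 3-cyanophenyl on the same core would test. A 3,4-dichlorophenyl would show whether adding chlorine to the 3-chlorophenyl keeps that number.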